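Chloro to methyl on two isatin-derived cores: cytotoxicity notes

A few compounds are considered here, and "the series" means these few. Any claim that something is new, unique, unknown or untested is made for them only; others in the source may bear on it.

Measured compounds:
compound 1 `COc1ccc(N2CCN(CN3C(=O)/C(=N\NC(=S)NO)c4cc(Cl)ccc43)CC2)cc1` — 279000 nM
compound 2 `COc1ccc(N2CCN(CN3C(=O)/C(=N\NC(=S)NO)c4cc(C)ccc43)CC2)cc1` — 321000 nM
compound 3 `CONC(=S)N/N=C1\C(=O)N(CN2CCN(c3c(F)cc4c(=O)c(C(=O)O)cn(C5CC5)c4c3OC)CC2C)c2ccc(Cl)cc21` — 164000 nM

In an ADME assay on MT4 cells (Homo sapiens) for cytotoxicity, read by spectrophotometry, with a stated time of 5 days (on this read-out lower numbers stand for higher toxicity in this test and higher numbers for lower toxicity in this test), compound 1 gives 279000 nM and compound 2 gives 321000 nM. The change between them is methyl in place of chloro on an aromatic carbon, and the step is a 1.2-fold higher number from compound 1 to compound 2 (0.06 log units; within the scatter), so the two numbers show no separation. Compound 3 gives 164000 nM in this assay; the difference between the core of compound 3 and the core of compound 1 is not broken down here, and its number lies within the scatter of both compound 1 and compound 2.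

Compound 4 `CONC(=S)N/N=C1\C(=O)N(CN2CCN(c3c(F)cc4c(=O)c(C(=O)O)cn(C5CC5)c4c3OC)CC2C)c2ccc(C)cc21` is not yet measured. It differs from compound 3 by methyl in place of chloro on an aromatic carbon, the same change as from compound 1 to compound 2, at the same place. Within the data shown here, with only one such step known, and that step within the scatter, the expected step in this assay is a 1.2-fold higher number from compound 3 to compound 4 (0.06 log units; within the scatter), resting on compound 3 at 164000 nM and on a 1.2-fold higher number from compound 1 to compound 2 (0.06 log units; within the scatter). For compound 4 the estimate in this assay is 190000 nM, between 100000 nM and 360000 nM.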

Compound 4, half-maximal cytotoxic concentration: 154000 nM
Compound 4: the middle estimate sits 1.2-fold (0.09 log units) above what was measured, and the stated range covers the measured number.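

In this assay, methyl in place of chloro on an aromatic carbon gives a 1.1-fold lower number from compound 3 to compound 4 (0.03 log units; within the scatter), so the swap produces no separation on this second core either. Set beside the first core, the two steps do not differ: the same change on two cores in this assay, a 1.2-fold higher number (0.06 log units; within the scatter) from compound 1 to compound 2 and a 1.1-fold lower number (0.03 log units; within the scatter) from compound 3 to compound 4, 1.2-fold (0.09 log units) apart, within the scatter of two such steps. Among these compounds, this shows that, on these two cores and in this one cytotoxicity read-out, exchanging chloro for methyl is neutral within the scatter, but with only two null steps it does not show that a real effect of the change would carry from one core to another, nor that the same neutrality would hold on any further core.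

The compounds shown carry only chloro or methyl at this place, so how a nitrile, a trifluoromethyl or a longer chain would read there remains open. Also open, going by these compounds, is whether the two cores would respond alike to a change large enough to move the number beyond the scatter.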